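Stereo inversion in the urea series, compound 2 to compound 3

The compounds below may be only part of what the source reports. "The series", "measured", "known", "first", "only" and "open" are said of these compounds alone.

Compound 1 `CCCCCCc1ccc(NC(=O)N[C@@H](C)c2ccccc2)cc1` and compound 2 `CCCCCCCc1ccc(NC(=O)N[C@H](C)c2ccccc2)cc1` are the measured members of the set. In an ADME assay on the whole organism with Oryza sativa as the target, tested at 1 uM (a higher number here means a weaker effect of the compound at the concentration tested, a lower number a stronger effect), compound 1 gives 100%, and in this assay compound 2 gives 100%. Compound 2 stands level with compound 1 at the digits shown, with no change beyond the scatter between the two values. Compound 3 `CCCCCCCc1ccc(NC(=O)N[C@@H](C)c2ccccc2)cc1` is not yet measured in this assay. Compound 3 differs from compound 2 as follows: the two compounds have the same atoms and bonds and differ only in configuration as drawn: 1 of 1 stereo elements differ; a stereocentre at a saturated chain carbon is drawn R in compound 2 and S in compound 3. Going by the values given here, no step between two measured compounds is available for this change, so the expectation rests on the values themselves. Both measured values sit at the same reading, which gives no sign that the configuration drawn matters here. For compound 3 the expected step from compound 2 is no change at the digits printed from compound 2 to compound 3 (within the scatter), that is, none beyond the scatter. Compound 3 is therefore estimated at 100% in this assay, within the range 88% to 100%.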

Compound 3, a percentage reported as activity, at one concentration (the size of the read-out at that concentration, not a potency): 99%
The estimate for compound 3 lay 1 percentage points above the measured number; the measured number falls inside the stated range.
By their numbers in this assay, from the lowest: compounds 3, 1 and 2 (each within the scatter of the next).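

In this assay, the configuration at the stereocentre on the saturated chain carbon now has a direct reading, with a number 1 percentage points lower from compound 2 to compound 3 (within the scatter); compounds 1 and 2 differ in two places and could not give this. Compound 3 also gives a single-place reading for methyl in place of hydrogen on a saturated chain carbon, six bonds along the chain from an aromatic carbon, with a number 1 percentage points lower from compound 1 to compound 3 (within the scatter). Neither change moves the read-out beyond the scatter, and the reading for configuration comes from a clean pair: the fact that compounds 2 and 3 differ only in the configuration as drawn

On these data alone, all three numbers lie at the weak end of the read-out, so it stays open whether configuration or chain length would matter in compounds with a stronger effect. Also open, as far as these compounds go, is whether an amine or a carboxylic acid in place of the chain would lower the number in this assay.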